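Compound 4 after a within-scatter methoxy shift

The compounds below may be only part of what the source reports. "The series", "measured", "known", "first", "only" and "open" are said of these compounds alone.

Values from a functional assay on HCT-116 cells (Homo sapiens) for antiproliferative activity, with a stated time of 72 h (a higher number here means a weaker inhibitor, a lower number a stronger inhibitor), follow.
Compound 1 `COc1ccccc1/C=C/c1nc2ccccc2c(=O)[nH]1` gives 1460 nM
Compound 2 `COc1ccccc1/C=C/c1nc(Nc2cccc(O)c2)c2ccccc2n1` gives 16400 nM
Compound 3 `COc1ccc(/C=C/c2nc(Nc3cccc(O)c3)c3ccccc3n2)cc1` gives 22900 nM

Compound 3 at 22900 nM lies within the scatter of compound 2 and well above compound 1 on these numbers. Compound 4 `O=[N+]([O-])c1cccc(/C=C/c2nc(Nc3cccc(O)c3)c3ccccc3n2)c1` differs from compound 3 by carrying 3-nitrophenyl in place of 4-methoxyphenyl on a double-bonded chain carbon bound to a double-bonded chain carbon, a change that reads 3-nitrophenyl in place of 4-methoxyphenyl on a double-bonded chain carbon bound to a double-bonded chain carbon and leaves the rest of the structure as it was.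

Within the data shown here, only one measured step bears on this place, a 1.4-fold higher number from compound 2 to compound 3 (0.14 log units; within the scatter) with 4-methoxyphenyl in place of 2-methoxyphenyl, and it stays within the scatter. Among the measured compounds shown here, no compound carrying 3-nitrophenyl has a value yet, so that single small step is thin support and the range must stay wide. On this evidence no step beyond the scatter is expected in this assay for this exchange. Put as a step, the expected change is a 1.4-fold lower number from compound 3 to compound 4 (0.16 log units; within the scatter) and this is an estimate only. For compound 4 the estimate is an expected 16000 nM within an expected range of 6000 nM to 45000 nM in this read-out.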

Compound 4, half-maximal inhibitory concentration: 10800 nM
The estimate for compound 4 lay 1.5-fold (0.17 log units) above the measured number, and the stated range covers the measured number.
By their numbers in this assay, from the lowest: compound 1; then compounds 4, 2 and 3 (each within the scatter of the next, the first and the last beyond it).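

In this assay, among these compounds, the only earlier step at this position, on a double-bonded chain carbon bound to a double-bonded chain carbon, stayed within the scatter, whereas the exchange of 4-methoxyphenyl for 3-nitrophenyl gives the first step there that goes beyond it (a 2.1-fold lower number from compound 3 to compound 4 (0.33 log units; beyond the scatter)). That step is modest and does not set 3-nitrophenyl apart from both methoxyphenyl groups, since the exchange of 2-methoxyphenyl for 3-nitrophenyl stays within the scatter (a 1.5-fold lower number from compound 2 to compound 4 (0.18 log units; within the scatter)). The position therefore shows some sensitivity to the group it carries, but only against 4-methoxyphenyl, and nothing available here accounts for the difference.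

The compounds shown leave open whether the step follows the nitro group itself or its place on the phenyl ring, a question that 3-methoxyphenyl and 4-nitrophenyl at this position would help to settle. They also leave open how a phenyl ring bearing an amine or a carboxylic acid would read at this position, and whether any such group would produce a step larger than the modest one seen here.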